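The source may hold more compounds than are shown below. What is called first, only, known or untested is meant among the compounds shown, and "the series" means these compounds.

Series notes. In an ADME assay for permeability, using PAMPA, at pH 5.5 (on this read-out lower numbers stand for lower permeability and higher numbers for higher permeability), compound 1 `CC(C)COc1ncc(-c2cn(C)c3cc(C(=O)NS(C)(=O)=O)ccc23)cc1Cl` gives 443 nm/s. For the measured compounds named here, this is the lowest of the three numbers so far, though each gap to the others falls within the usual scatter: compound 3 `Cn1cc(-c2ccc(C(F)(F)F)cc2)c2ccc(C(=O)NS(=O)(=O)C3CC3)cc21` gives 525 nm/s, the nearest number, and compound 2 `CC(C)COc1ccc(-c2nn(C)c3cc(C(=O)NS(=O)(=O)C4CC4)c(F)cc23)cn1` gives 762 nm/s, the furthest. Going by the values given here, no pair of measured compounds differs in only one place, so no single-change step in this assay is available to lean on.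

Compound 4 `CC(C)COc1ncc(-c2cn(C)c3cc(C(=O)NS(C)(=O)=O)c(F)cc23)cc1Cl` has not yet been measured in this assay. It differs from compound 1 in one place: fluoro in place of hydrogen on an aromatic carbon. With no measured step of this kind in hand, the expected step is a 1.1-fold higher number from compound 1 to compound 4 (0.05 log units; within the scatter), which is no change beyond the scatter; if anything the lean is toward a higher number, and compound 2, which also carries a fluoro on its core, sits in the same broad range at 762 nm/s. For compound 4 the estimate in this assay is 500 nm/s, with a range from 250 nm/s to 1000 nm/s.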

Compound 4, apparent permeability: 495 nm/s
Estimate against measurement, compound 4: 1.0-fold (0.00 log units) above, and the stated range covers the measured number.
By their numbers in this assay, from the lowest: compounds 1, 4, 3 and 2 (each within the scatter of the next).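

In this assay, for the compounds shown here, fluoro in place of hydrogen on an aromatic carbon, ortho to a (methylsulfonyl)carbamoyl group, gives a 1.1-fold higher number from compound 1 to compound 4 (0.05 log units; within the scatter) and so provides the first single-change step. Going by these compounds alone, at this position, the change therefore leaves compound 4 level with compound 1 within the scatter, which the earlier compounds, all differing in more than one place, could not show. No measured property is at hand to explain the size of this step.

From the compounds shown here alone, whether a different group at the same position, such as a methoxy group, an amine or a nitrile, would also leave the read-out level remains open. Going by these compounds, it is also open whether the fluoro step would hold with a cyclopropyl group in place of the methyl group on the sulfonyl.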